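Replacing the furan of compound 2 with an ester

A few compounds are considered here, and "the series" means these few. Any claim that something is new, unique, unknown or untested is made for them only; others in the source may bear on it.

In a functional assay on MCF7 cells (Homo sapiens) for antiproliferative activity, read by MTT assay, with a stated time of 72 h (on this read-out lower numbers stand for stronger inhibition of growth and higher numbers for weaker inhibition of growth), compound 2 `c1ccc(/N=c2\ssnc2-c2ccco2)cc1` gives 10000 nM. Compound 1 `Fc1ccc(-c2nss/c2=N\c2ccccc2)cc1` gives 10000 nM, so at the digits shown compound 2 stands level with compound 1, within the scatter. Compound 3 `Cc1nss/c1=N\c1ccccc1` gives > 10000 nM, which is a limit of the assay rather than a number. The step of a number no lower from compound 2 to compound 3 (the limit leaves the size open) is therefore open in size, because the limit of > 10000 nM in this assay, at which 1 of the 3 values shown sits, leaves it unreadable.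

Compound 4 `CCOC(=O)c1nss/c1=N\c1ccccc1` is not yet measured. It differs from compound 2 by ethoxycarbonyl in place of furan-2-yl on an aromatic carbon. Among the measured compounds shown here, the only measured step that bears on this change is the one in which the furan-2-yl also left, replaced by methyl; there the number went no lower, and how far it moved could not be read. For the measured compounds named here, nothing among the measured compounds shows an ethoxycarbonyl on this carbon, so the expectation rests on that single step alone. Compound 4 is accordingly expected to show a step of no change at the digits printed from compound 2 to compound 4 (within the scatter) that is either nothing beyond the scatter or a move toward weaker growth inhibition that may again end at the limit. Compound 4 is estimated at 10000 nM, in a range from 5000 nM to 30000 nM.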

Compound 4, concentration for 50% growth inhibition: > 10000 nM
Compound 4 ended at the assay's limit; the forecaster's own chance of this, stated with the estimate: 50%; the middle value sits exactly at the limit.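

In this assay compound 4 gives > 10000 nM, which is a limit of the assay and not a number. Placing ethoxycarbonyl on the aromatic carbon next to the ring nitrogen gives a number no lower from compound 2 to compound 4 (the limit leaves the size open), so a second replacement for furan-2-yl, this one carrying a carbonyl and no ring, brings no lower number, just as methyl did. The size of this step and the comparison between compound 3 and compound 4 cannot be read, because these compounds end at a limit: the limit of > 10000 nM in this assay, at which 2 of the 4 values shown sit.

What the compounds shown leave open is whether any group on this carbon gives a lower number than compound 2, since none shown here does so. An amine, a carboxylic acid or a longer chain in place of furan-2-yl would test this, and only a compound with a value inside the range of the assay could show how large such a step is.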